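Methoxy in Place of Chloro: Expected Effect on Cytotoxicity

A few compounds are considered here, and "the series" means these few. Any claim that something is new, unique, unknown or untested is made for them only; others in the source may bear on it.

The three measured compounds were all tested in a functional assay on M14 cells (Homo sapiens) for cytotoxicity, read by MTT assay, with a stated time of 72 h; a higher number here means a weaker inhibitor, a lower number a stronger inhibitor.
Compound 1 `CC(=O)n1cc(/C=C(/C(=O)O)c2ccc(Cl)cc2)c2cc(OCc3ccccc3)ccc21` gives > 100000 nM, which is a limit of the assay and not a number.
Compound 2 `O=C(O)/C(=C/c1c[nH]c2ccc(OCc3ccccc3)cc12)c1ccccc1` gives 95200 nM.
Compound 3 `COc1ccc(/C(=C\c2cn(C(C)=O)c3ccc(OCc4ccccc4)cc23)C(=O)O)cc1OC` gives 65500 nM.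

Compound 1 thus stands at the boundary of what this assay reports: its result is only a limit (the limit of > 100000 nM in this assay, at which 1 of the 3 values shown sits), so no exact number is known for it. The unmeasured compound 4 `COc1ccc(/C(=C\c2cn(C(C)=O)c3ccc(OCc4ccccc4)cc23)C(=O)O)cc1` differs from compound 1 in one place: methoxy in place of chloro on an aromatic carbon. Within the data shown here, one measured step bears on this change. Exchanging the 4-chlorophenyl of compound 1 for 3,4-dimethoxyphenyl gave an at least 1.5-fold lower number from compound 1 to compound 3 (0.18 log units; that floor lies within the scatter). Compound 4 carries a single methoxy and so lies between these two in structure; the step to it is expected to be small, toward a lower number, and may well stay within the scatter. The expected step is an at least 1.2-fold lower number from compound 1 to compound 4 (0.09 log units; that floor lies within the scatter). Given the limit of > 100000 nM in this assay, at which 1 of the 3 values shown sits, for compound 1, the result for compound 4 could itself come back as a limit rather than a number. Compound 4 is estimated at 80000 nM, with a range from 40000 nM to 160000 nM.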

Compound 4, half-maximal inhibitory concentration: > 100000 nM
Compound 4 was reported as a limit; the forecaster's own chance of this, stated with the estimate: 35%; middle value at least 1.2-fold (0.09 log units) away from the limit.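

In this assay compound 4 gives > 100000 nM, which is a limit of the assay and not a number. Methoxy in place of chloro, para to a large group, therefore yields no readable change, and the step between compound 1 and compound 4 cannot be read because both compounds end at the same limit: the limit of > 100000 nM in this assay, at which 2 of the 4 values shown sit. The new information comes from the comparison with compound 3, where hydrogen in place of methoxy on an aromatic carbon gives an at least 1.5-fold higher number from compound 3 to compound 4 (0.18 log units; that floor lies within the scatter), so among compound 1, compound 3 and compound 4, only compound 3 gives a number rather than a limit, although the printed floor of this step stays within the scatter.

On these data alone, how far compound 1 and compound 4 lie beyond the reported range remains unknown, so chloro and methoxy cannot be placed in order at this position. The compounds shown also leave open whether an amine or a hydroxyl group in the same place, or an ethoxy group with its longer chain, would give a number rather than a limit.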